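This account rests on a few compounds, and the source may have more. Where it says the series, first, only, none or still open, it means among the compounds named here.

In an ADME assay on THP-1 cells (Homo sapiens) for cytotoxicity, read by flow cytometry and propidium iodide staining, with a stated time of 72 h (on this read-out lower numbers stand for stronger inhibition and higher numbers for weaker inhibition), compound 1 `COc1cccc(-c2cc(=O)c3cc(NC(C)=O)ccc3o2)c1` gives 10000 nM. Compound 2 `COc1cccc(-c2cc(=O)c3cc(N)ccc3o2)c1` returns only a limit, > 125000 nM, and no number. Within the data shown here, the one measured step, an at least 12-fold higher number from compound 1 to compound 2 (1.09 log units; beyond the scatter), is large, but it concerns the group on the nitrogen. Compound 3 `Nc1ccc2oc(-c3cccc(C(F)(F)F)c3)cc(=O)c2c1` keeps that nitrogen as in compound 2 and differs by trifluoromethyl in place of methoxy on an aromatic carbon. Among the measured compounds shown here, no measured step covers this change, so no shift beyond the scatter is expected in this assay. The expected outcome is an at least 1.3-fold lower number from compound 2 to compound 3 (0.14 log units; that floor lies within the scatter). For compound 3 the estimated value is 90000 nM, with an expected range of 30000 nM to 200000 nM.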

Compound 3, half-maximal inhibitory concentration: 34000 nM
Beside the measured number, compound 3's estimate is 2.6-fold (0.42 log units) above it; the range from low to high includes it.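

In this assay, the aromatic carbon meta to a large group now proves to matter as well, whereas earlier only the group on the nitrogen had moved the number. With that nitrogen unchanged, trifluoromethyl in place of methoxy gives an at least 3.6-fold lower number from compound 2 to compound 3 (0.56 log units; beyond the scatter). This step is only a floor, as compound 2 carries a limit and not a number: the limit of > 125000 nM in this assay, at which 1 of the 3 values shown sits.

Going by these compounds, whether trifluoromethyl and the acetyl on the nitrogen would act together remains open. So does what a nitrile, a chlorine or a carboxylic acid would do on this aromatic carbon.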